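This account rests on a few compounds, and the source may have more. Where it says the series, first, only, none or still open, it means among the compounds named here.

Measured compounds and their values:

Compound 2, `OC[C@H]1O[C@H](Oc2ccc(-c3ccccc3Cl)cc2Cl)[C@@H](O)[C@@H](O)[C@@H]1O` — 3.1
Compound 3, `OC[C@H]1O[C@H](Oc2ccc(-c3ccc(Cl)cc3)cc2Cl)[C@@H](O)[C@@H](O)[C@@H]1O` — 3.3
Compound 1, `OC[C@H]1O[C@H](Oc2ccc(-c3ccc(Cl)cc3Cl)cc2Cl)[C@@H](O)[C@@H](O)[C@@H]1O` — "not determined" (no result reported)

Compound 1 stands on no single number: in a physicochemical assay for lipophilicity, read by LC-MS, measured as octanol-water partition, with a stated time of 2 h, at pH 7.4, tested at 1 uM (a higher number here means a more lipophilic compound, a lower number a more polar compound), compound 1 is recorded as "not determined" (no result reported), so there is no measured starting point for the step to compound 4. The two measured compounds frame the series. In this assay, among the compounds with values here, compound 2 gives 3.1, and compound 3 gives 3.3; the one measured step, a number 0.20 log units higher from compound 2 to compound 3 (within the scatter), shows that moving a single chloro group around the distal ring leaves the distribution coefficient within the scatter.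

Compound 4, `CC(=O)c1ccc(-c2ccc(O[C@H]3O[C@H](CO)[C@@H](O)[C@H](O)[C@@H]3O)c(Cl)c2)cc1`, differs from compound 1 in one place: 4-acetylphenyl in place of 2,4-dichlorophenyl on an aromatic carbon. Neither measured step covers this change; the step from compound 2 to compound 3 only shows that the two chlorophenyl variants sit close together. Within the data shown here, the entering 4-acetylphenyl brings one hydrogen-bond acceptor where the leaving 2,4-dichlorophenyl brought none, and both measured compounds carry a chlorophenyl group, so no measured compound tells directly how far compound 4 will move.

Taking the values of compound 2 and compound 3 as the only anchors, compound 4 is expected to read lower in this assay, estimated at 2.3, with a range from 1.7 to 2.9.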

Compound 4, distribution coefficient: 2.1
The estimate for compound 4 lay 0.20 log units above the measured number; measured number inside the range.
By their numbers in this assay, from the lowest: compound 4; then compounds 2 and 3 (each within the scatter of the next).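

In this assay, within the data shown here, the earlier compounds showed only that a chloro group could sit at two places on the distal ring without the number leaving the scatter; the new result shows that the number at this position does respond once the group itself changes, with acetyl in place of chloro giving a number 1.20 log units lower from compound 3 to compound 4 (beyond the scatter) in the closest comparison. The change from 2-chlorophenyl to 4-acetylphenyl points the same way, giving a number 1.00 log units lower from compound 2 to compound 4 (beyond the scatter), so compound 4 stands apart from both chlorophenyl compounds, wherever their chloro group sits. Nothing at hand explains the size of this fall or tells which feature of the entering group accounts for it.

On these data alone, compound 1 has no number, so the change from 2,4-dichlorophenyl to 4-acetylphenyl cannot itself be read, and what a second chloro group on the distal ring does to the number stays open. The compounds shown also leave open whether a nitrile, a carboxylic acid, an amine or a longer ketone chain on the same ring would lower the number as far, and whether the acetyl group would give a similar step at another place on that ring.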